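This account rests on a few compounds, and the source may have more. Where it says the series, first, only, none or still open, it means among the compounds named here.

Compound 1 `COc1cccc(NC(=O)NC2CC(C)(C)Oc3ccc(F)cc32)c1` was tested in a functional assay (aorta) with Rattus norvegicus as the target; on this read-out higher numbers stand for an effect only at larger amounts of compound and lower numbers for an effect already at smaller amounts. In this assay compound 1 gives > 10000 nM, which is a limit of the assay and not a number.
Compound 2 `COc1cccc(NC(=O)NC2CC(C)(C)Oc3ccc(Br)cc32)c1` was tested in the same way. In this assay compound 2 gives > 10000 nM, again a limit rather than a measured number.

Going by the values given here, compound 2 therefore stands at the edge of what this assay reports: both values sit at the limit of > 10000 nM in this assay, at which 2 of the 2 values shown sit, and the one measured step, a step that the two limits leave unreadable from compound 1 to compound 2, cannot be read because both ends are limits. Compound 3 `CC1(C)CC(NC(=O)Nc2ccc(Cl)cc2)c2cc(Br)ccc2O1` is still to be measured. It differs from compound 2 in that (4-chlorophenyl in place of 3-methoxyphenyl on an amide-type nitrogen). Among the compounds with values here, no measured step touches the group on the amide-type nitrogen; the only step recorded concerns the halogen on the aromatic carbon and is itself unreadable. Nothing in the data thus points either way for the step from compound 2 to compound 3. Compound 3 is expected to show a step of about an at least 1.2-fold lower number from compound 2 to compound 3 (0.09 log units; that floor lies within the scatter), and its value is estimated at 8000 nM, within a range from 1500 nM to 30000 nM, with a real chance that the assay again returns only a limit.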

Compound 3, half-maximal effective concentration: > 300000 nM
Compound 3: only a limit was reported; the forecaster's own chance of this, stated with the estimate: 65%; middle value at least 37-fold (1.57 log units) away from the limit.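

Compound 2 and compound 3 are both reported only as limits in this assay, so the step between them, 4-chlorophenyl in place of 3-methoxyphenyl on the amide-type nitrogen, cannot be read. Compound 3 has a limit of its own: the limit of > 300000 nM in this assay, at which 1 of the 3 values shown sits.

The compounds shown leave open whether any of them gives a measured number in this assay, and how far either change would shift one.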